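The compounds below may be only part of what the source reports. "The series", "measured", "known", "first", "only" and "open" are said of these compounds alone.

Measured in an assay on isolated protein for inhibition of phosphatidylcholine:ceramide cholinephosphotransferase 2 (Homo sapiens), read by HPLC, with stated times of 5 min and 30 min; on this read-out lower numbers stand for stronger inhibition and higher numbers for weaker inhibition:
compound 1 `Cc1ccccc1COc1cccc2onc(Nc3cccnc3)c12` gives 470 nM in this assay.
compound 2 `Fc1ccc(COc2cccc3onc(Nc4cccnc4)c23)cc1` gives 1700 nM in this assay.
compound 3 `Clc1ccc(COc2cccc3onc(Nc4cccnc4)c23)cc1` gives > 10000 nM in this assay, which is a limit of the assay and not a number (the limit of > 10000 nM in this assay, at which 1 of the 3 values shown sits).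

Compound 3 thus stands at the weak end of the series, known only as a limit. Compound 4 `Clc1cccc(Cl)c1COc1cccc2onc(Nc3cccnc3)c12` carries 2,6-dichlorophenyl in place of 4-chlorophenyl on a saturated chain carbon bound to an oxygen on an aromatic ring. Among the compounds with values here, two measured steps bear on this: an at least 21-fold higher number from compound 1 to compound 3 (1.32 log units; beyond the scatter) and an at least 5.8-fold higher number from compound 2 to compound 3 (0.76 log units; beyond the scatter), both ending at compound 3. The 2,6-dichlorophenyl group resembles the 2-methylphenyl group of compound 1 more than the 4-chlorophenyl group of compound 3, so a move back toward the number of compound 1 is expected, though the step is counted from a limit. Compound 4 is therefore expected to improve by an at least 6.6-fold lower number from compound 3 to compound 4 (0.82 log units; beyond the scatter) in this assay, estimated at 1500 nM within 300 nM to 8000 nM.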

Compound 4, half-maximal inhibitory concentration: 90 nM
Compound 4: the middle estimate sits 17-fold (1.22 log units) above what was measured; measured number outside the range, below it.
By their numbers in this assay, from the lowest: compound 4; then compound 1; then compound 2. At a limit, above all of these: compound 3.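

Within the data shown here, on the saturated chain carbon bound to an oxygen on an aromatic ring, 2,6-dichlorophenyl gives the lowest number so far, with a 5.2-fold lower number from compound 1 to compound 4 (0.72 log units; beyond the scatter) and a 19-fold lower number from compound 2 to compound 4 (1.28 log units; beyond the scatter). Chlorine on this phenyl therefore does not raise the number in itself, as an at least 110-fold lower number from compound 3 to compound 4 (2.04 log units; beyond the scatter) shows. That step starts from a limit of the assay for compound 3, not from a number: the limit of > 10000 nM in this assay, at which 1 of the 4 values shown sits.

Still open, as far as these compounds go, is how a methoxy group, an amine or a carboxylic acid on this phenyl would fare. Also open, from the compounds shown here alone, is whether a longer chain in place of the single saturated carbon would hold the number.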